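Adding an Amino Group to Two Nucleoside Cores

The source may hold more compounds than are shown below. What is called first, only, known or untested is meant among the compounds shown, and "the series" means these compounds.

Compound 2 `C#Cc1cn([C@@H]2O[C@H](CO)[C@@H](O)[C@H]2O)c2ncnc(OC)c12` carries a methoxy group and an ethynyl group on its core. In a functional assay on HL-60 cells (Homo sapiens) for antiproliferative activity, read by XTT assay, with a stated time of 72 h (on this read-out lower numbers stand for stronger inhibition and higher numbers for weaker inhibition), compound 2 gives 190 nM. Compound 1 `C#Cc1cn([C@@H]2O[C@H](CO)[C@@H](O)[C@H]2O)c2nc(N)nc(OC)c12` differs from it in one place: amino in place of hydrogen on an aromatic carbon. In this assay compound 1 reaches only a limit of the assay, > 20000 nM. The step is an at least 100-fold higher number from compound 2 to compound 1 (2.02 log units; beyond the scatter), ending at the limit of > 20000 nM in this assay, at which 2 of the 3 values shown sit.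

Compound 3 `O=c1[nH]cnc2c1c(-c1ccccc1)cn2[C@@H]1O[C@H](CO)[C@@H](O)[C@H]1O` has a core bearing a phenyl group; the difference between the two cores is not broken down here. In this assay compound 3 likewise reaches only a limit of the assay, > 20000 nM. Compound 4 `Nc1nc2c(c(-c3ccccc3)cn2[C@@H]2O[C@H](CO)[C@@H](O)[C@H]2O)c(=O)[nH]1` is not yet measured and differs from compound 3 in one place: amino in place of hydrogen on an aromatic carbon. Among the compounds with values here, this is the same kind of change as the one leading to compound 1, though the surroundings differ: there the amino sits meta to a methoxy group (2 heavy atoms), here meta to a group of 1 heavy atom.

Compound 3 already sits at a limit, and the earlier change weakened inhibition strongly, so the step that the limit leaves unreadable from compound 3 to compound 4 is expected to leave compound 4 at a limit as well. Compound 4 is therefore estimated at 50000 nM in this assay, resting on compound 3 giving > 20000 nM and on the step of an at least 100-fold higher number from compound 2 to compound 1 (2.02 log units; beyond the scatter).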

Compound 4, half-maximal inhibitory concentration: > 20000 nM
Compound 4 gave a limit, no number (the forecaster's own chance of this, stated with the estimate: 85%); the middle value lies beyond the limit too.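

Compound 3 and compound 4 each stop at a limit rather than a number in this assay, so no step between them can be read: the limit of > 20000 nM in this assay, at which 3 of the 4 values shown sit.

The compounds shown leave open whether the amino group changes inhibition at all on the core of compound 3, and so whether the large weakening seen with compound 2 and compound 1 also holds on this second core.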